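The compounds below may be only part of what the source reports. "The series", "measured", "known", "first", "only" and "open" are said of these compounds alone.

Measured so far:
compound 1, `O=C(Nc1cccc(-c2ccc(CO)cc2)c1)c1ccccc1`: in an assay for binding affinity to 17-beta-hydroxysteroid dehydrogenase type 2 (Homo sapiens), with a stated time of 20 min, tested at 1 uM (on this read-out higher numbers stand for more inhibition at the one concentration tested (going by the name of the read-out) and lower numbers for less inhibition), compound 1 gives < 10%
compound 2, `CN(C(=O)c1ccccc1)c1cccc(-c2ccc(CO)cc2)c1`: in this assay compound 2 gives < 10%.

The value of compound 1 in this assay is a limit of the assay, not a number. The value of compound 2 there is likewise only a limit. Compound 2 therefore stands at the floor of what this assay reports, with no numerical placement. Within the data shown here, the one measured step, a step that the two limits leave unreadable from compound 1 to compound 2, methyl in place of hydrogen on an amide-type nitrogen, cannot be read because of the limit of < 10% in this assay, at which 2 of the 2 values shown sit.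

Compound 3, `COc1ccc(C(=O)N(C)c2cccc(-c3ccc(CO)cc3)c2)cc1`, is not yet measured. It differs from compound 2 by methoxy in place of hydrogen on an aromatic carbon. Among the measured compounds shown here, no measured step bears on a change of this kind, and the single step available carries no readable size. Nothing in the data points to movement off the limit in this assay. Compound 3 is expected at 7%, within 0% to 25%. The expected step that the limit leaves unreadable from compound 2 to compound 3 is nominal only, with no readable basis in the measured pair.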

Compound 3, a percentage reported as inhibition, at one concentration (the size of the read-out at that concentration, not a potency): 14%
Beside the measured number, compound 3's estimate is 7 percentage points below it, and the stated range covers the measured number.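

In this assay, among these compounds, compound 3 gives 14%, the only number among the values shown rather than a limit. Among the compounds shown here, the change from phenyl to 4-methoxyphenyl, on an aromatic carbon para to a large group, is the only change at this position, and it reads as a number at least 4 percentage points higher from compound 2 to compound 3 (that floor lies within the scatter). Methoxy at this position therefore moves the read-out off the limit, but whether the step exceeds the usual scatter remains undecided.

On these data alone, the step on the amide-type nitrogen still cannot be read, so the effect of that methyl on a methoxy-bearing compound also remains unknown: the limit of < 10% in this assay, at which 2 of the 3 values shown sit. Also open is whether the number depends on methoxy itself, which an amine, a carboxylic acid or a longer alkoxy chain on the same carbon would test.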